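Chain length and antiproliferative potency in an adenine-derived series

This account rests on a few compounds, and the source may have more. Where it says the series, first, only, none or still open, it means among the compounds named here.

Two members of this series have been characterised. Compound 1, `CCCCCCCCCCCCCCCCCC/N=c1\nc(N)c2nc[nH]c2c(N)n1`, carries an octadecyl chain on the double-bonded nitrogen, and in a functional assay on NCI-H460 cells (Homo sapiens) for antiproliferative activity, read by WST assay, with a stated time of 72 h (a higher number here means a weaker inhibitor, a lower number a stronger inhibitor), compound 1 gives 1750 nM. Compound 2, `CC/N=c1\nc(N)c2nc[nH]c2c(N)n1`, carries only an ethyl chain at that position, and in this assay compound 2 gives 22000 nM. Of the two numbers, compound 2 stands highest, and the gap to compound 1 lies beyond the usual scatter, so compound 2 is the weaker inhibitor of the pair.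

Compound 3, `CCCCCCCC/N=c1\nc(N)c2nc[nH]c2c(N)n1`, is an intermediate: the change from compound 2 is hexyl in place of hydrogen on a saturated chain carbon, two bonds along the chain from a double-bonded nitrogen, giving an octyl chain. Among the compounds with values here, no directly comparable step has been measured. Given that the long-chain compound 1 sits at 1750 nM and the short-chain compound 2 at 22000 nM, compound 3 is expected to fall toward the stronger side, with the step from compound 2 to compound 3 in this assay estimated at a 4.4-fold lower number from compound 2 to compound 3 (0.64 log units; beyond the scatter). For compound 3 in this assay the estimate is 5000 nM, with a range from 1500 nM to 15000 nM.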

Compound 3, half-maximal inhibitory concentration: "not active" (no number reported)
No number was reported for compound 3, so the estimate cannot be set against anything.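

With no number reported for compound 3 in this assay, no step can be read that links compound 3 to compound 2 or compound 1. The compounds shown leave open how activity runs with chain length between the ethyl chain of compound 2 and the octadecyl chain of compound 1. Nothing at hand bears on this result.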